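The source may report more compounds than this note shows. Statements on the series, on what has been measured and on what is new or still open speak of the compounds shown alone.

Compound 3 `CC#C[C@@H](CC(=O)O)c1ccc(OC[C@H]2COc3ccc(C#N)cc3O2)cc1` gives 2100 nM in a functional assay on HEK293 cells for agonist activity at Free fatty acid receptor 1 (Homo sapiens), read by fluorescence and calcium flux, with a stated time of 10 min (a lower number here means that less compound is needed, a higher number that more compound is needed for the effect), the highest of the three numbers measured: compound 1 `CC#C[C@@H](CC(=O)O)c1ccc(OC[C@H]2COc3ccc(C)cc3O2)cc1` gives 120 nM and compound 2 `CC#C[C@@H](CC(=O)O)c1ccc(OC[C@H]2COc3ccc(OC)cc3O2)cc1` gives 130 nM, and the steps of an 18-fold higher number from compound 1 to compound 3 (1.24 log units; beyond the scatter) and a 16-fold higher number from compound 2 to compound 3 (1.21 log units; beyond the scatter) are both large. Compound 4 `CC#C[C@@H](CC(=O)O)c1ccc(OC[C@H]2COc3ccc(S(C)(=O)=O)cc3O2)cc1` differs from compound 3 by methylsulfonyl in place of cyano on an aromatic carbon. Among the measured compounds shown here, no measured step exchanges a cyano for a methylsulfonyl group, so the two steps into compound 3 bear on it only in showing that a change at this carbon moves the number a great deal. Compound 4 is therefore expected to shift by a 1.4-fold lower number from compound 3 to compound 4 (0.15 log units; within the scatter), an uncertain call. Compound 4 is estimated at 1500 nM, with a range from 400 nM to 6000 nM.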

Compound 4, half-maximal effective concentration: 27200 nM
Beside the measured number, compound 4's estimate is 18-fold (1.26 log units) below it; measured number outside the range, above it.
By their numbers in this assay, from the lowest: compounds 1 and 2 (each within the scatter of the next); then compound 3; then compound 4.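

Methylsulfonyl at this aromatic carbon goes well beyond cyano in this assay, with a 13-fold higher number from compound 3 to compound 4 (1.11 log units; beyond the scatter), so these two groups are clearly separated, although each gives a much higher number than methyl and methoxy. The span at this carbon now reaches a 210-fold higher number from compound 2 to compound 4 (2.32 log units; beyond the scatter) and a 230-fold higher number from compound 1 to compound 4 (2.36 log units; beyond the scatter), and compound 4 has the highest number of the four compounds. Nothing given here explains this order. Going by these compounds, it remains open whether an amine or a hydroxyl group at this carbon would give a number like that of compound 1 or like that of compound 4, and whether the same order would hold at another carbon of this ring.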